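Lengthening the Saturated Chain of Compound 2

A few compounds are considered here, and "the series" means these few. Any claim that something is new, unique, unknown or untested is made for them only; others in the source may bear on it.

Three compounds have been measured in a functional assay on A-431 cells (Homo sapiens) for cytotoxicity, read by MTT assay, with a stated time of 48 h; on this read-out higher numbers stand for weaker inhibition and lower numbers for stronger inhibition:

compound 1, `CCCCCCCCCCCCCCNC(=O)[C@@H](NC(=O)c1ccccc1)[C@@H](C)O`, gives 118000 nM
compound 2, `CCCCCCCCCCCCCCNC(=O)[C@@H](NC(=O)c1nccc2ccccc12)[C@@H](C)O`, gives 23000 nM
compound 3, `CCCCCCCCCCCCCCNC(=O)[C@@H](NC(=O)/C=C/c1ccccc1)[C@@H](C)O`, gives 64900 nM

Compound 2 has the lowest number of the three. The step from the phenyl of compound 1 to the isoquinolin-1-yl of compound 2 reads a 5.1-fold lower number from compound 1 to compound 2 (0.71 log units; beyond the scatter), and the step onward to the 2-phenylethenyl of compound 3 reads a 2.8-fold higher number from compound 2 to compound 3 (0.45 log units; beyond the scatter). Between compound 1 and compound 3 the step is a 1.8-fold lower number from compound 1 to compound 3 (0.26 log units; within the scatter), so those two cannot be ordered.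

Compound 4, `CCCCCCCCCCCCCCCCCCNC(=O)[C@@H](NC(=O)c1nccc2ccccc12)[C@@H](C)O`, keeps the isoquinolin-1-yl of compound 2 and differs from it only by butyl in place of hydrogen on a saturated chain carbon, ten or more bonds along the chain from an amide-type nitrogen. Among the compounds with values here, none of the measured steps bears on this change: all three vary the group on the carbonyl carbon and leave the saturated chain untouched. There is therefore no measured basis for expecting a shift in either direction, and the step from compound 2 to compound 4 is expected to be no change at the digits printed from compound 2 to compound 4 (within the scatter), within the scatter. The estimate for compound 4 in this assay is 23000 nM, with a range from 7000 nM to 75000 nM that reflects the absence of any comparable step.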

Compound 4, half-maximal inhibitory concentration: 44100 nM
Estimate against measurement, compound 4: 1.9-fold (0.28 log units) below; the measured number falls inside the stated range.
By their numbers in this assay, from the lowest: compounds 2, 4, 3 and 1 (each within the scatter of the next, the first and the last beyond it).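

In this assay, within the data shown here, the only step here that touches the saturated chain, butyl in place of hydrogen on a saturated chain carbon, ten or more bonds along the chain from an amide-type nitrogen, reads a 1.9-fold higher number from compound 2 to compound 4 (0.28 log units; within the scatter). The earlier steps shown here varied only the group on the carbonyl carbon, and two of them lay beyond the scatter, whereas this first reading of the chain shows that, with the isoquinolin-1-yl in place, adding butyl at this position produces no difference that can be told apart from repeat-measurement noise. This is a single step on a single compound, and nothing available here offers an explanation for the reading or tests it by another kind of measurement.

As far as these compounds go, it remains open whether a chain shorter than that of compound 2, or one longer than that of compound 4, would stay equally flat, and whether an amine or a carboxylic acid on this saturated chain would read differently. Also open, from the compounds shown here alone, is whether the same butyl change would read alike with the phenyl of compound 1 or the 2-phenylethenyl of compound 3.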